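From a Hydroxyethyl Chain to a Pyridinylmethoxy Group

This account rests on a few compounds, and the source may have more. Where it says the series, first, only, none or still open, it means among the compounds named here.

Among the compounds with values here, compound 2 `Cn1cnc2c(C#N)nc(-c3ccc(CCO)c(C(F)(F)F)c3)cc21` sits at the higher of the two numbers so far: in an assay on isolated protein for inhibition of cathepsin S (Homo sapiens), read by fluorescence (a higher number here means a weaker inhibitor, a lower number a stronger inhibitor), compound 2 gives 71 nM, while compound 1 `CCOc1ccc(-c2cc3c(ncn3C)c(C#N)n2)cc1C(F)(F)F` gives 40 nM, and a 1.8-fold higher number from compound 1 to compound 2 (0.25 log units; within the scatter). Compound 3 `Cn1cnc2c(C#N)nc(-c3ccc(OCc4cccnc4)c(C(F)(F)F)c3)cc21` carries the change ((pyridin-3-yl)methoxy in place of 2-hydroxyethyl on an aromatic carbon). Within the data shown here, only the step from compound 1 to compound 2 touches this aromatic carbon, and it stayed within the scatter, so exchanging the group there has so far left the number roughly unchanged. Among the measured compounds shown here, a considerably larger group now enters, and no measured step shows what that does. The estimate for compound 3 is therefore 60 nM, with a range from 20 nM to 200 nM. This means an expected step of a 1.2-fold lower number from compound 2 to compound 3 (0.07 log units; within the scatter), which need not exceed the scatter.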

Compound 3, half-maximal inhibitory concentration: 12.6 nM
Compound 3: the middle estimate sits 4.8-fold (0.68 log units) above what was measured, outside the stated range (below it).
By their numbers in this assay, from the lowest: compound 3; then compounds 1 and 2 (each within the scatter of the next).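

In this assay, within the data shown here, the change gives a 5.6-fold lower number from compound 2 to compound 3 (0.75 log units; beyond the scatter) and is the first step at this aromatic carbon to lie beyond the scatter. Measured against the ethoxy group, it gives a 3.2-fold lower number from compound 1 to compound 3 (0.50 log units; beyond the scatter) as well, so the number at this place does respond to the group, and the larger (pyridin-3-yl)methoxy group goes with the lower value. No evidence is available to explain this result. On these data alone, whether the lower number depends on the ring nitrogen or on where that nitrogen stands remains open, and a benzyloxy or (pyridin-4-yl)methoxy group would test this.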